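The compounds below may be only part of what the source reports. "The series", "measured", "known", "first", "only" and "open" are said of these compounds alone.

Notes on the amide series, read in a functional assay on ACHN cells (Homo sapiens) for cytotoxicity, read by sulforhodamine B assay, with a stated time of 72 h; a lower number here means a stronger inhibitor of growth, a higher number a weaker inhibitor of growth. Compound 1 `O=C(Nc1ccc(C(F)(F)F)cc1)C1CCc2ccccc2N1` gives 25000 nM. Compound 3 `COc1ccc(NC(=O)C2CCc3ccccc3N2)cc1` gives 38000 nM, and the step of a 1.5-fold higher number from compound 1 to compound 3 (0.18 log units; within the scatter) is within the scatter. For compound 2 `CCCC(=O)N1c2ccccc2CCC1C(=O)Nc1ccccc1C(F)(F)F` only a limit is reported, > 70000 nM, as recorded in the limit of > 70000 nM in this assay, at which 1 of the 3 values shown sits. Compound 4 `CC(=O)N1c2ccccc2CCC1C(=O)Nc1ccccc1C(F)(F)F` remains to be measured. The change is hydrogen in place of ethyl on a saturated chain carbon bound to a carbonyl carbon. Within the data shown here, no measured step touches the acyl chain; the single measured step concerns the aromatic ring and was within the scatter, so it offers no guidance on this change. With compound 2 sitting at a limit, no shift beyond the scatter is expected in this assay. Compound 4 is therefore estimated at 80000 nM, range 30000 nM to 200000 nM. The expected step is a step that the limit leaves unreadable from compound 2 to compound 4, most likely another limit.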

Compound 4, concentration for 50% growth inhibition: > 80000 nM
Compound 4: no number, only a limit; the forecaster's own chance of this, stated with the estimate: 60%; the middle value sits exactly at the limit.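

In this assay compound 2 gives only a limit, > 70000 nM. Compound 4 also gives only a limit, > 80000 nM, and the step from compound 2 to compound 4 cannot be read. The compounds shown leave open how the change from propylcarbonyl to acetyl affects growth inhibition.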